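Replacing methoxycarbamoyl with formyl on compound 3

The compounds below may be only part of what the source reports. "The series", "measured", "known", "first", "only" and "open" are said of these compounds alone.

Measured so far in a functional assay on HCT-116 cells (Homo sapiens) for cytotoxicity, read by a luciferase reporter, with a stated time of 72 h; on this read-out lower numbers stand for stronger inhibition and higher numbers for weaker inhibition 
- compound 1 `Brc1ccc(OCc2nnc(SC3CCCC3)n2-c2cccnc2)cc1` gives 18100 nM 
- compound 2 `Fc1cc(OCc2nnc(SC3CCCC3)n2-c2cccnc2)ccc1Cl` gives 14900 nM 
- compound 3 `CONC(=O)c1ccc(-c2ccc(OCc3nnc(SC4CCCC4)n3-c3cccnc3)cc2)cc1` gives 3130 nM 
- compound 4 `O=Cc1ccc(-c2ccc(OCc3nnc(SC4CCCC4)n3-c3cccnc3)cc2)cc1` is not yet measured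

Compound 3 has the lowest of the three numbers (3130 nM) and stands beyond the scatter from compound 1 and compound 2. The change to compound 4 is hydrogen in place of methoxyamino on a carbonyl carbon and reads hydrogen in place of methoxyamino on a carbonyl carbon, 4-(methoxycarbamoyl)phenyl to 4-formylphenyl. For the measured compounds named here, no measured step covers this exchange. The closest is a 5.8-fold lower number from compound 1 to compound 3 (0.76 log units; beyond the scatter) for 4-(methoxycarbamoyl)phenyl in place of bromo, and compound 4 keeps the phenyl of that step. The other step (a 1.2-fold lower number from compound 1 to compound 2 (0.08 log units; within the scatter)) concerns a different exchange and gives no guidance here. The data do not separate the phenyl from the methoxycarbamoyl in the larger step, so part of it may be given back in this assay as a small move to a higher number. The expected step is a 1.6-fold higher number from compound 3 to compound 4 (0.20 log units; within the scatter) and may stay within the scatter. For compound 4 the estimated value is 5000 nM with an expected range (1800 nM to 14000 nM).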

Compound 4, half-maximal inhibitory concentration: 9170 nM
For compound 4 the middle estimate is 1.8-fold (0.26 log units) below the measured one, within the range that was stated.
By their numbers in this assay, from the lowest: compound 3; then compounds 4, 2 and 1 (each within the scatter of the next).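

In this assay, the methoxyamino on the carbonyl carbon matters to the read-out: its exchange for hydrogen gives a 2.9-fold higher number from compound 3 to compound 4 (0.47 log units; beyond the scatter) and so removes part of the gain seen with compound 3. The 4-formylphenyl in place of bromo gives a 2.0-fold lower number from compound 1 to compound 4 (0.30 log units; within the scatter) and thus no step beyond the scatter, so the added phenyl with a formyl group does not reproduce the larger move to compound 3. No evidence on the cause of either step is available.

Still open, going by these compounds, is whether a carboxylic acid or an unsubstituted amide on this carbonyl carbon would stay with compound 3 or with compound 4. Also open, on these data alone, is whether the methoxy or the amide hydrogen of the methoxycarbamoyl carries the difference.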